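A few compounds are considered here, and "the series" means these few. Any claim that something is new, unique, unknown or untested is made for them only; others in the source may bear on it.

Measured so far in an assay on a protein complex for inhibition of CDK8/Cyclin C (Homo sapiens), with a stated time of 1 h, tested at 10 uM; a higher number here means more inhibition at the concentration tested (going by the name of the read-out), a lower number less inhibition:
Compound 1 `O=C(/C=C/c1ccncc1-c1ccc2ccccc2c1)NC1CC1` gives 102%.
Compound 2 `O=C(O)CCNC(=O)/C=C/c1ccncc1-c1ccc2ccccc2c1` gives 91%.
Compound 3 `COC(=O)CCc1ccncc1-c1ccc2ccccc2c1` gives 98%.

Compound 3 holds the second highest of these three numbers. Its nearest neighbour is compound 1, and the step of a number 4 percentage points lower from compound 1 to compound 3 (within the scatter) lies within the usual scatter, so the two cannot be told apart. Compound 2 shows a somewhat lower number than compound 3, but that gap is also within the scatter.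

Compound 4 `CN(C)C(=O)/C=C/c1ccncc1-c1ccc2ccccc2c1` differs from compound 3 in one place: 2-(dimethylcarbamoyl)ethenyl in place of 2-(methoxycarbonyl)ethyl on an aromatic carbon. Going by the values given here, two measured steps bear on this. The step of a number 4 percentage points lower from compound 1 to compound 3 (within the scatter) changed the same position and left the number essentially unchanged. The step of a number 11 percentage points lower from compound 1 to compound 2 (beyond the scatter) altered what sits on the amide-type nitrogen and cost a modest amount, beyond the scatter. Compound 4 carries an amide-type group on an ethenyl chain, as compound 1 does, but without an amide hydrogen; nothing measured here isolates that feature. Since every group tried at this position has kept the number high, only a small shift is expected, a number 1 percentage points lower from compound 3 to compound 4 (within the scatter), in no firm direction. Compound 4 is therefore estimated at 97%, in a range of 86% to 105%.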

Compound 4, a percentage reported as inhibition, at one concentration (the size of the read-out at that concentration, not a potency): 100%
Compound 4: the middle estimate sits 3 percentage points below what was measured; low and high end bracket the measured number.
By their numbers in this assay, from the lowest: compounds 2, 3, 4 and 1 (each within the scatter of the next, the first and the last beyond it).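

In this assay, the step of a number 2 percentage points lower from compound 1 to compound 4 (within the scatter) shows that dimethylamino can replace cyclopropylamino on the carbonyl carbon without a readable loss, so the amide hydrogen of compound 1 is not required for a high number at this concentration. The step of a number 2 percentage points higher from compound 3 to compound 4 (within the scatter) adds that 2-(dimethylcarbamoyl)ethenyl and 2-(methoxycarbonyl)ethyl cannot be told apart at this place on the aromatic carbon, even though the two chains differ in their linking double bond and in carrying an amide rather than an ester. The step of a number 9 percentage points higher from compound 2 to compound 4 (within the scatter) also stays within the scatter, so on the carbonyl carbon dimethylamino cannot be separated from (2-carboxyethyl)amino, just as it cannot be separated from cyclopropylamino.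

Nothing available gives a reason why the number stays level across such different groups here. From the compounds shown here alone, it remains open whether a simple amine or a longer chain at this place on the aromatic carbon would keep the number this high, and a single tested concentration cannot show whether these compounds differ in potency.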